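Urea to cyclohexyl amide on the shared core

The source may hold more compounds than are shown below. What is called first, only, known or untested is meant among the compounds shown, and "the series" means these compounds.

Among the compounds with values here, compound 2 `C[C@@H](NC(=O)Nc1ccc(Cl)cc1)[C@H]1CC[C@@H](c2ccnc3ccc(F)cc32)CC1` holds the only number in an assay on blood for inhibition of Indoleamine 2,3-dioxygenase 1 (Homo sapiens), read by mass spectrometry, with stated times of 4 h and 18 h (a lower number here means a stronger inhibitor, a higher number a weaker inhibitor), giving 280 nM. Compound 1 `C[C@@H](NCc1ccc(Cl)cc1)[C@H]1CC[C@@H](c2ccnc3ccc(F)cc32)CC1` gives > 1000 nM in this assay, which is a limit and not a number. The step of an at least 3.5-fold lower number from compound 1 to compound 2 (0.55 log units; beyond the scatter) is therefore a bound only, because it rests on (the limit of > 1000 nM in this assay, at which 1 of the 2 values shown sits). Compound 3 `C[C@@H](NC(=O)C1CCCCC1)[C@H]1CC[C@@H](c2ccnc3ccc(F)cc32)CC1` differs from compound 2 by cyclohexyl in place of (4-chlorophenyl)amino on a carbonyl carbon. Within the data shown here, no measured step touches the carbonyl substituent, so the only comparison is indirect. A weakening beyond the scatter is expected for compound 3, estimated at 700 nM within 250 nM to 2500 nM, a step of a 2.5-fold higher number from compound 2 to compound 3 (0.40 log units; beyond the scatter).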

Compound 3, half-maximal inhibitory concentration: 294 nM
The estimate for compound 3 lay 2.4-fold (0.38 log units) above the measured number, and the stated range covers the measured number.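

In this assay, cyclohexyl in place of (4-chlorophenyl)amino on a carbonyl carbon gives a 1.1-fold higher number from compound 2 to compound 3 (0.02 log units; within the scatter). This pair therefore shows no dependence on the aromatic ring, the chlorine or the hydrogen-bond donor of the leaving group, which go out together. With the cyclohexyl amide, the carbonyl-bearing side again separates from the benzylamine with an at least 3.4-fold lower number from compound 1 to compound 3 (0.53 log units; beyond the scatter), a bound only, as the value of compound 1 is a limit: the limit of > 1000 nM in this assay, at which 1 of the 3 values shown sits.

Open, from the compounds shown here alone, is how far the carbonyl substituent accepts other groups, such as a methyl, a morpholine or a cyclohexyl carrying a carboxylic acid. Whether the carbonyl alone accounts for the step from the benzylamine also stays open.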